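Z to E geometry at a butyl alkyne

The source may hold more compounds than are shown below. What is called first, only, known or untested is meant among the compounds shown, and "the series" means these compounds.

In a functional assay on HeLa cells (Homo sapiens) for antiproliferative activity, read by MTT assay, with a stated time of 3 days (a higher number here means a weaker inhibitor, a lower number a stronger inhibitor), compound 1 `Cc1ccc(C#Cc2cn(C/C=C\CN3C(=O)c4ccccc4C3=O)c(=O)[nH]c2=O)cc1` gives > 100000 nM, which is a limit of the assay and not a number. Compound 2 `O=C1c2ccccc2C(=O)N1C/C=C\Cn1cc(C#Cc2ccc(Br)cc2)c(=O)[nH]c1=O` gives 87000 nM. Compound 3 `CCCCC#Cc1cn(C/C=C\CN2C(=O)c3ccccc3C2=O)c(=O)[nH]c1=O` gives 33000 nM, the lower of the two actual numbers in the series.

The measured steps all concern the substituent on the triple bond. Bromo in place of methyl on an aromatic carbon gives an at least 1.1-fold lower number from compound 1 to compound 2 (0.06 log units; that floor lies within the scatter). Butyl in place of 4-methylphenyl gives an at least 3.0-fold lower number from compound 1 to compound 3 (0.48 log units; beyond the scatter), and butyl in place of 4-bromophenyl gives a 2.6-fold lower number from compound 2 to compound 3 (0.42 log units; beyond the scatter).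

Compound 4 `CCCCC#Cc1cn(C/C=C/CN2C(=O)c3ccccc3C2=O)c(=O)[nH]c1=O` keeps the butyl group of compound 3: the two compounds have the same atoms and bonds and differ only in configuration as drawn: 1 of 1 stereo elements differ; a double bond is drawn Z in compound 3 and E in compound 4. A double bond is drawn Z in compound 3 and E in compound 4. Going by the values given here, all three measured compounds carry the Z form, so no measured step tests this change directly, and the direction of any shift remains open. The modest size of a 2.6-fold lower number from compound 2 to compound 3 (0.42 log units; beyond the scatter) gives only a rough guide, so no step beyond the scatter is expected in this assay, though a modest one in either direction would not be surprising. The expected change is a 1.1-fold higher number from compound 3 to compound 4 (0.04 log units; within the scatter). For compound 4 the estimated value is 36000 nM, with an expected range from 14000 nM to 90000 nM.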

Compound 4, half-maximal inhibitory concentration: 89000 nM
Estimate against measurement, compound 4: 2.5-fold (0.39 log units) below; the range from low to high includes it.
By their numbers in this assay, from the lowest: compound 3; then compounds 2 and 4 (each within the scatter of the next). At a limit, above all of these: compound 1.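

Going by these compounds alone, the earlier compounds all carried the Z form and differed only in the substituent on the triple bond, so this is the first step to show that the geometry of the double bond itself moves the number in this assay: with the butyl group kept, the change from Z to E gives a 2.7-fold higher number from compound 3 to compound 4 (0.43 log units; beyond the scatter). That step is modest, as is a 2.6-fold lower number from compound 2 to compound 3 (0.42 log units; beyond the scatter), so in this short series the geometry counts for about as much as that exchange of substituent on the triple bond. Because nothing else changes, the shift belongs to the geometry alone: the fact that compounds 3 and 4 differ only in the configuration as drawn

The compounds shown leave open whether the change from Z to E has the same direction with the 4-bromophenyl group of compound 2 or the 4-methylphenyl group of compound 1 on the triple bond. They also leave open how a longer alkyl chain or a chain ending in a hydroxyl group on the triple bond, or a saturated chain in place of the double bond, would compare with the Z and E forms.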